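The compounds below may be only part of what the source reports. "The series", "measured", "known", "first", "only" and "open" are said of these compounds alone.

Of the compounds shown here, three have been measured in an in vitro assay on COS-7 cells for displacement of a labelled ligand from prostaglandin D2 receptor 2 (Homo sapiens); a higher number here means a weaker inhibitor, a lower number a stronger inhibitor. Compound 1 `COc1ccccc1Nc1nc(-c2ccc(F)cc2)c(CC(=O)O)s1` gives 1500 nM in this assay. Compound 2 `COc1ccccc1Nc1nc(-c2ccc(Cl)cc2)c(CC(=O)O)s1`, which carries the same core, gives 450 nM in this assay. The step between them, a 3.3-fold higher number from compound 2 to compound 1 (0.52 log units; beyond the scatter), corresponds to fluoro in place of chloro on an aromatic carbon. Compound 3 `O=C(O)Cc1sc(Cc2ccccc2)nc1-c1ccc(Cl)cc1` has a different core; the difference between the two cores is not broken down here. In this assay compound 3 gives 180 nM, the lowest of the three numbers, and its steps to compound 2 and compound 1 are both beyond the scatter.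

Compound 4 `O=C(O)Cc1sc(Cc2ccccc2)nc1-c1ccc(F)cc1` has not yet been measured in this assay. It differs from compound 3 by fluoro in place of chloro on an aromatic carbon, and the place of this change is the same, word for word, as the place of the change from compound 2 to compound 1, so it is the same change seen a second time, this time on the core of compound 3.

Among the compounds with values here, on this basis the step is expected to be a 3.1-fold higher number from compound 3 to compound 4 (0.49 log units; beyond the scatter), beside the earlier 3.3-fold higher number from compound 2 to compound 1 (0.52 log units; beyond the scatter), because the single measured instance of this change gave a 3.3-fold higher number from compound 2 to compound 1 (0.52 log units; beyond the scatter). The expectation rests on one pair only, and whether the change carries over to a different core is not known. Compound 4 is therefore estimated at 550 nM in this assay, with a plausible range from 250 nM to 1300 nM.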

Compound 4, half-maximal inhibitory concentration: 140 nM
The estimate for compound 4 lay 3.9-fold (0.59 log units) above the measured number; measured number below the stated range.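

In this assay, the exchange of 4-chlorophenyl for 4-fluorophenyl on the core of compound 3 gives a 1.3-fold lower number from compound 3 to compound 4 (0.11 log units; within the scatter), so on this core the two groups cannot be told apart, whereas on the core of compound 1 the same exchange gives a step beyond the scatter. The change therefore does not carry over between these two cores as a fixed step: the same change on two cores in this assay, a 3.3-fold higher number (0.52 log units; beyond the scatter) from compound 2 to compound 1 and a 1.3-fold lower number (0.11 log units; within the scatter) from compound 3 to compound 4, 4.3-fold (0.63 log units) apart, beyond the scatter of two such steps. This shows that in this series the size of the step can depend on the core that carries it, but with a single pair on each core it does not show which part of the cores is responsible, or how the change would behave on any further core.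

The compounds shown leave open whether other groups in the same place on the aromatic ring, such as bromo, methyl, methoxy or trifluoromethyl, or plain hydrogen there, would also separate the two cores. They also leave open whether the contrast between the cores would survive if the carboxylic acid gave way to an amide or the acetic acid chain were replaced by a longer chain.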